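This account rests on a few compounds, and the source may have more. Where it says the series, first, only, none or still open, it means among the compounds named here.

Measured compounds:
Compound 1 `Cc1cc(NC(=O)Nc2ccc(C(C)(C)C)cc2)c2ccccc2n1` gives 17000 nM in an ADME assay on HepG2 cells (Homo sapiens) for cytotoxicity, with a stated time of 72 h; on this read-out higher numbers stand for an effect only at larger amounts of compound and lower numbers for an effect already at smaller amounts.
Compound 2 `COc1ccc(NC(=O)Nc2cc(C)nc3ccccc23)cc1OC` reaches only the limit > 25000 nM in this assay.
Compound 3 `COc1ccc(NC(=O)Nc2cc(C)nc3ccccc23)cc1Cl` likewise stops at the limit > 25000 nM in this assay.

Going by the values given here, compound 1 is the single value that is an actual number in this set; the other two are limits of the assay, and the limit of > 25000 nM in this assay, at which 2 of the 3 values shown sit, marks where they sit. The step that the two limits leave unreadable from compound 2 to compound 3 is therefore unreadable, and it concerns the other aryl side of the shared core anyway.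

Compound 4 `Cc1cc(NC(=O)Nc2ccc(C(=O)O)cc2)c2ccccc2n1` is not yet measured. It differs from compound 1 by carboxy in place of tert-butyl on an aromatic carbon.

Among the compounds with values here, no measured step touches a change on the same ring position, so the expectation for this assay can rest only on the standing of compound 1 and on the fact that two of three compounds already reach the limit. A step no larger than the usual scatter, or a shift toward the limit, is expected. For compound 4 the estimated value is 25000 nM, between 12000 nM and 60000 nM. The expected step is a 1.5-fold higher number from compound 1 to compound 4 (0.17 log units; within the scatter).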

Compound 4, half-maximal effective concentration: > 25000 nM
Compound 4 was reported as a limit (the forecaster's own chance of this, stated with the estimate: 50%); the middle value sits exactly at the limit.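

In this assay compound 4 gives > 25000 nM as a limit and not a number. Going by these compounds alone, on an aromatic carbon para to a large group, carboxy in place of tert-butyl gives an at least 1.4-fold higher number from compound 1 to compound 4 (0.16 log units; that floor lies within the scatter) and thereby provides the first readable step, though only as a floor. Within the data shown here, compound 1 remains the only compound with an actual number, while the other compounds share one limit: the limit of > 25000 nM in this assay, at which 3 of the 4 values shown sit.

Going by these compounds, how far compound 4 lies from compound 1 stays open, and the step from compound 2 to compound 3 cannot be read. The compounds shown also leave open whether an amine, a methyl ester or a longer chain in the same place would give an actual number or reach the limit.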